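A few compounds are considered here, and "the series" means these few. Any claim that something is new, unique, unknown or untested is made for them only; others in the source may bear on it.

In a functional assay on HeLa cells (Homo sapiens) for inhibition, read by CCK-8 assay, with a stated time of 48 h (on this read-out lower numbers stand for stronger inhibition and higher numbers for weaker inhibition), compound 1 (`COc1cc(-c2ccnc3cc(-c4ccccc4)nn23)cc(OC)c1OC`) gives 458 nM and compound 2 (`COc1cc(-c2ccnc3cc(-c4ccc(N(C)C)cc4)nn23)cc(OC)c1OC`) gives 378 nM as a close pair, while compound 3 (`COc1cc(-c2ccnc3cc(-c4ccc(C(C)=O)cc4)nn23)cc(OC)c1OC`) gives 1810 nM as the highest number of the three. Compound 4 (`CCOC(=O)c1ccc(-c2cc3nccc(-c4cc(OC)c(OC)c(OC)c4)n3n2)cc1`) carries ethoxy in place of methyl on a carbonyl carbon, turning acetyl into ethoxycarbonyl. Going by the values given here, no measured step makes this exact change. Acetyl brought a 4.0-fold higher number from compound 1 to compound 3 (0.60 log units; beyond the scatter) and, against dimethylamino, a 4.8-fold higher number from compound 2 to compound 3 (0.68 log units; beyond the scatter) while dimethylamino itself brought a 1.2-fold lower number from compound 1 to compound 2 (0.08 log units; within the scatter) in the same series. Compound 4 keeps the carbonyl of compound 3 (1810 nM) and so should stay near it. A step of a 1.1-fold lower number from compound 3 to compound 4 (0.05 log units; within the scatter) is expected, with no shift beyond the scatter in either direction. For compound 4 the estimate is 1600 nM (expected range 650 nM to 4000 nM).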

Compound 4, half-maximal inhibitory concentration: > 10000 nM
Compound 4: a limit, no number; the forecaster's own chance of this, stated with the estimate: 3%; middle value at least 6.2-fold (0.79 log units) away from the limit.
By their numbers in this assay, from the lowest: compounds 2 and 1 (each within the scatter of the next); then compound 3. At a limit, above all of these: compound 4.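

In this assay compound 4 stands at a limit of the assay, not at a number: the limit of > 10000 nM in this assay, at which 1 of the 4 values shown sits.

Keeping the carbonyl therefore does not keep the number: ethoxy in place of methyl on the carbonyl carbon gives an at least 5.5-fold higher number from compound 3 to compound 4 (0.74 log units; beyond the scatter). Against the other groups on that aromatic carbon, ethoxycarbonyl gives an at least 26-fold higher number from compound 2 to compound 4 (1.42 log units; beyond the scatter) and an at least 21-fold higher number from compound 1 to compound 4 (1.33 log units; beyond the scatter).

As far as these compounds go, whether a carboxylic acid or an amide on that carbonyl carbon would go the same way stays open. So does the effect of a chain longer than ethoxy.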